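The source may report more compounds than this note shows. Statements on the series, on what has been measured and on what is new or still open speak of the compounds shown alone.

Measured compounds:
Compound 1, `COc1cc(/C=C/c2nc(NCc3ccc(C)cc3)c3sccc3n2)cc(OC)c1OC`: > 1000000 nM
Compound 2, `COc1ccc(CNc2nc(/C=C/c3cc(OC)c(OC)c(OC)c3)nc3ccsc23)cc1`: > 1000000 nM

In a functional assay on L02 cells (Homo sapiens) for inhibition, read by Griess assay, with stated times of 1 h and 24 h (a lower number here means a stronger inhibitor, a higher number a weaker inhibitor), compound 1 gives only a limit of the assay, > 1000000 nM. In this assay compound 2 also gives a limit and no number, > 1000000 nM. The step that the two limits leave unreadable from compound 1 to compound 2 cannot be read because of the limit of > 1000000 nM in this assay, at which 2 of the 2 values shown sit. So compound 2 stands at the limit, with no measured number to place it more exactly.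

Compound 3, `COc1cc(/C=C/c2nc(OCc3ccccc3)c3sccc3n2)cc(OC)c1OC`, is not yet measured. It differs from compound 2 by benzyloxy in place of (4-methoxybenzyl)amino on an aromatic carbon. For the measured compounds named here, none of the measured steps bears on this change with a readable size, since the one available comparison, from compound 1 to compound 2, stays between two limits and shows neither direction nor size. With compound 2 at a limit in this assay, the expected step that the limit leaves unreadable from compound 2 to compound 3 is none beyond the scatter. Compound 3 is therefore expected to give roughly 1500000 nM in this assay, within 200000 nM to 10000000 nM, most probably reported again as a limit.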

Compound 3, half-maximal inhibitory concentration: > 1000000 nM
Compound 3: only a limit was reported; the forecaster's own chance of this, stated with the estimate: 70%; the middle value lies beyond the limit too.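

The result for compound 3 is again only a limit, as for compound 1 and compound 2, so no step among the three can be read in this assay: the limit of > 1000000 nM in this assay, at which 3 of the 3 values shown sit.

From the compounds shown here alone, whether benzyloxy in place of (4-methoxybenzyl)amino changes inhibition at all, and in which direction, stays open.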